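A new aromatic group on the faster-cleared compound

The source may report more compounds than this note shows. Statements on the series, on what has been measured and on what is new or still open speak of the compounds shown alone.

Within the data shown here, in an ADME assay (liver) for metabolic stability, with Liver microsome (Rattus norvegicus) as the target, using microsomes and NADPH, with a stated time of 30 min, tested at 1 uM (on this read-out higher numbers stand for fast clearance and lower numbers for slow clearance), compound 1 `Nc1ccc(S(=O)(=O)N2CCN(c3ncc(C(O)(C(F)(F)F)C(F)(F)F)cc3C#CCO)CC2)cn1` gives 65 mL.min-1.g-1 and compound 2 `Cc1csc(-c2cc(C(O)(C(F)(F)F)C(F)(F)F)cnc2N2CCN(S(=O)(=O)c3ccc(N)nc3)CC2)c1` gives 399 mL.min-1.g-1 as the higher of only two numbers. Among the measured compounds shown here, these two compounds differ in one place, and the measured step there, a 6.1-fold higher number from compound 1 to compound 2 (0.79 log units; beyond the scatter) (the only step available), is the sole guide to what a change at that place can do. Compound 3 `CS(=O)(=O)Nc1cccc(-c2cc(C(O)(C(F)(F)F)C(F)(F)F)cnc2N2CCN(S(=O)(=O)c3ccc(N)nc3)CC2)c1` alters the same place again, with 3-(methanesulfonamido)phenyl in place of 4-methylthiophen-2-yl on an aromatic carbon and the rest of the structure unchanged.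

A single step cannot predict a new group, and the entering group matches neither of the groups measured so far. Since compound 2 at 399 mL.min-1.g-1 is already the top of the measured range, a move down towards compound 1 seems likelier than a further rise, probably by less than the measured step. The expected change is a 2.5-fold lower number from compound 2 to compound 3 (0.40 log units; beyond the scatter) and it remains uncertain. Compound 3 is estimated at 160 mL.min-1.g-1 with a likely range from 60 mL.min-1.g-1 to 400 mL.min-1.g-1 on this read-out.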

Compound 3, intrinsic clearance in microsomes: 81 mL.min-1.g-1
Compound 3: middle estimate off by 2.0-fold (0.30 log units), on the high side, within the range that was stated.
By their numbers in this assay, from the lowest: compounds 1 and 3 (each within the scatter of the next); then compound 2.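

In this assay, the new step, a 4.9-fold lower number from compound 2 to compound 3 (0.69 log units; beyond the scatter), shows that an aromatic ring at this place, ortho to a large group and two atoms from the ring nitrogen, does not by itself bring the high number seen with 4-methylthiophen-2-yl. The other new step, a 1.2-fold higher number from compound 1 to compound 3 (0.10 log units; within the scatter), shows that two very different groups, 3-(methanesulfonamido)phenyl with its aromatic ring and the ring-free 3-hydroxyprop-1-yn-1-yl, cannot be told apart on this read-out, so this place allows low clearance numbers with more than one kind of group. Nothing measured here tells which feature of these groups lies behind the two steps.

From the compounds shown here alone, the change from 4-methylthiophen-2-yl to 3-(methanesulfonamido)phenyl alters the ring and its substituent together, so it remains open which of the two goes with the lower number, and an unsubstituted phenyl at this place would help to separate them. Going by these compounds, it also remains open how the number would respond to a different substituent on that ring, such as a carboxylic acid or an amine.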